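The source may hold more compounds than are shown below. What is called first, only, known or untested is meant among the compounds shown, and "the series" means these compounds.

Measured compounds in the series:

compound 1 `COc1c(OCCCCN2CCN(C)CC2)cc(O)c2c(=O)cc(-c3ccc(C)cc3)oc12` — in a functional assay on A549 cells (Homo sapiens) for cytotoxicity, read by MTT assay, with a stated time of 72 h (a higher number here means a weaker inhibitor, a lower number a stronger inhibitor), compound 1 gives 3810 nM
compound 2 `COc1c(OCCCCN2CCN(C)CC2)cc(O)c2c(=O)cc(-c3ccc(C(F)(F)F)cc3)oc12` — compound 2 gives 2890 nM
compound 3 `COc1c(OCCCCN2CCN(C)CC2)cc(O)c2c(=O)cc(-c3ccc(F)cc3)oc12` — compound 3 gives 2220 nM

Compound 2 stands second highest of the three numbers in this assay. Its neighbours lie close on both sides: a 1.3-fold lower number from compound 1 to compound 2 (0.12 log units; within the scatter) and a 1.3-fold lower number from compound 2 to compound 3 (0.11 log units; within the scatter), both within the scatter, so the three compounds cannot be separated on these data.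

Compound 4 `COc1c(OCCCCN2CCN(C)CC2)cc(O)c2c(=O)cc(-c3ccc(F)cc3Br)oc12` is the next member, not yet measured. The change from compound 2 is 2-bromo-4-fluorophenyl in place of 4-(trifluoromethyl)phenyl on an aromatic carbon. For the measured compounds named here, the steps that bear on it are the three exchanges of the substituent on the phenyl group: a 1.3-fold lower number from compound 1 to compound 2 (0.12 log units; within the scatter), a 1.7-fold lower number from compound 1 to compound 3 (0.23 log units; within the scatter) and a 1.3-fold lower number from compound 2 to compound 3 (0.11 log units; within the scatter), all within the scatter. Going by the values given here, every variation of this group so far has left this assay essentially unchanged; the new step adds a bromo substituent, which no measured pair covers, so the expectation rests on the flat trend alone, with somewhat wider uncertainty.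

No step beyond the scatter is expected in this assay for compound 4. Compound 4 is estimated at 2500 nM, with a range from 1000 nM to 6500 nM. For compound 4 the expected step is a 1.2-fold lower number from compound 2 to compound 4 (0.06 log units; within the scatter).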

Compound 4, half-maximal inhibitory concentration: 2980 nM
For compound 4 the middle estimate is 1.2-fold (0.08 log units) below the measured one; low and high end bracket the measured number.
By their numbers in this assay, from the lowest: compounds 3, 2, 4 and 1 (each within the scatter of the next).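

In this assay, for the compounds shown here, compound 4 is the first to add a substituent to the phenyl group rather than exchange one, and bromo in place of hydrogen gives a 1.3-fold higher number from compound 3 to compound 4 (0.13 log units; within the scatter) within a pair that differs at that one place alone. Against the two other phenyl groups, the full exchange gives a 1.0-fold higher number from compound 2 to compound 4 (0.01 log units; within the scatter) and a 1.3-fold lower number from compound 1 to compound 4 (0.11 log units; within the scatter) as well, so the flat picture at this position now extends to a phenyl group carrying two substituents, and all four compounds remain inseparable on these data. No supporting data are available to explain why these changes leave the number so little moved.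

From the compounds shown here alone, all four phenyl groups carry only methyl, trifluoromethyl or halogen substituents, so it remains open whether an amine, a hydroxyl or a carboxylic acid on that ring, or a nitrogen within the ring itself, would move the number beyond the scatter. The chain on the shared core is the same throughout, which leaves open how far a shorter or longer chain would shift the number in this assay when the phenyl group is held constant.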